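Moving from 4-fluorobenzyl to 3-fluorobenzyl: a small expected step

A few compounds are considered here, and "the series" means these few. Any claim that something is new, unique, unknown or untested is made for them only; others in the source may bear on it.

Measured so far in a functional assay on B16 cells (Mus musculus) for antiproliferative activity, read by MTT assay, with a stated time of 24 h; a higher number here means a weaker inhibitor, a lower number a stronger inhibitor:
- Compound 1 `COc1cc(OC)c(-c2coc3cc(OCc4ccc(F)cc4)ccc3c2=O)cc1OC` gives 1120 nM
- Compound 2 `COc1cc(OC)c(-c2coc3cc(OCc4ccccc4C)ccc3c2=O)cc1OC` gives 2150 nM

For the measured compounds named here, compound 1 cannot be separated from compound 2, its only measured neighbour, with a 1.9-fold higher number from compound 1 to compound 2 (0.28 log units; within the scatter). The unmeasured compound 3 `COc1cc(OC)c(-c2coc3cc(OCc4cccc(F)c4)ccc3c2=O)cc1OC` follows from compound 1 by 3-fluorophenyl in place of 4-fluorophenyl on a saturated chain carbon bound to an oxygen on an aromatic ring, placing 3-fluorophenyl where 4-fluorophenyl stood, on a saturated chain carbon bound to an oxygen on an aromatic ring. Going by the values given here, only one measured step, at this same place, bears on the change: compound 2 differs from compound 1 by a 1.9-fold higher number from compound 1 to compound 2 (0.28 log units; within the scatter). No shift beyond the scatter is therefore expected in this assay, in either direction. The estimated step is a 1.2-fold higher number from compound 1 to compound 3 (0.06 log units; within the scatter). Compound 3 is expected at 1300 nM, within an estimated range of 600 nM to 2800 nM.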

Compound 3, half-maximal inhibitory concentration: 2440 nM
For compound 3 the middle estimate is 1.9-fold (0.27 log units) below the measured one; the range from low to high includes it.
By their numbers in this assay, from the lowest: compounds 1, 2 and 3 (each within the scatter of the next, the first and the last beyond it).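

In this assay, for the compounds shown here, exchanging 4-fluorobenzyl for 3-fluorobenzyl gives the first step at this position to pass the scatter, though only modestly (a 2.2-fold higher number from compound 1 to compound 3 (0.34 log units; beyond the scatter)). The place therefore responds to where the fluorine sits on the phenyl ring, even with the atom count unchanged. Compound 3 cannot be separated from compound 2 (a 1.1-fold higher number from compound 2 to compound 3 (0.05 log units; within the scatter)), so 3-fluorophenyl and 2-methylphenyl remain indistinguishable here.

No available measurement explains the shift. Also open, on these data alone, is how this place would respond to an amine or a carboxylic acid on the phenyl ring in place of fluorine.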